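The source may hold more compounds than are shown below. What is called first, only, known or untested is meant among the compounds shown, and "the series" means these compounds.

In a functional assay on DLA cells (Mus musculus) for cytotoxicity, read by trypan blue exclusion, with a stated time of 48 h (on this read-out lower numbers stand for stronger inhibition and higher numbers for weaker inhibition), compound 1 `Cc1ccc(C(=O)c2ccc(OCC(=O)Nc3nc(-c4ccccc4)cs3)c(C)c2)cc1` gives 25000 nM, compound 3 `Cc1cc(C(=O)c2ccccc2)cc(C)c1OCC(=O)Nc1nc(-c2ccccc2)cs1` gives 19100 nM, and compound 2 `COc1ccc(-c2csc(NC(=O)COc3ccc(C(=O)c4ccc(C)cc4)cc3C)n2)cc1` gives 16000 nM. Among the measured compounds shown here, compound 2 sits at the low end of the three numbers, yet compound 3 and compound 1 both lie within the scatter of it; the one single-point step, a 1.6-fold lower number from compound 1 to compound 2 (0.19 log units; within the scatter), is also within the scatter. Compound 4 `COc1ccc(-c2csc(NC(=O)COc3ccc(C(=O)c4cccc(Br)c4)cc3C)n2)cc1` differs from compound 2 by 3-bromophenyl in place of 4-methylphenyl on a carbonyl carbon. For the measured compounds named here, no measured step touches this carbonyl-linked ring, so nothing among the three compounds speaks for a shift beyond the scatter in this assay, and compound 4 is expected to stay close to compound 2, with no change at the digits printed from compound 2 to compound 4 (within the scatter). The estimate for compound 4 is 16000 nM, within a range from 6000 nM to 40000 nM.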

Compound 4, half-maximal inhibitory concentration: 35400 nM
Compound 4: the middle estimate sits 2.2-fold (0.34 log units) below what was measured; the measured number falls inside the stated range.
By their numbers in this assay, from the lowest: compounds 2, 3, 1 and 4 (each within the scatter of the next, the first and the last beyond it).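

The ring on the carbonyl carbon is not a silent position in this assay: 3-bromophenyl in place of 4-methylphenyl gives a 2.2-fold higher number from compound 2 to compound 4 (0.34 log units; beyond the scatter) and so the first shift beyond the scatter, modest in size and towards weaker inhibition. The change moves the substituent and alters its identity at once, so this single step cannot separate the two. Nothing available accounts for the shift. On these data alone, it remains open whether 4-bromophenyl or 3-methylphenyl would follow compound 4 or compound 2 on this read-out.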